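A Phenylsulfonyl Group Takes the Place of 4-Fluorophenyl

A few compounds are considered here, and "the series" means these few. Any claim that something is new, unique, unknown or untested is made for them only; others in the source may bear on it.

Three measured compounds share one core and differ in a single group on it. Compound 1 `CCOC(=O)c1cnc(SC)nc1NN1C(=O)C=C(C)C1=O` carries methylsulfanyl there, and in a functional assay on Jurkat cells for inhibition of nuclear factor NF-kappa-B complex (Homo sapiens) (on this read-out higher numbers stand for weaker inhibition and lower numbers for stronger inhibition), compound 1 gives 200 nM. Compound 2 `CCOC(=O)c1cnc(-c2ccc(F)cc2)nc1NN1C(=O)C=C(C)C1=O` carries 4-fluorophenyl, and in this assay compound 2 gives 700 nM, the highest of the three numbers. Compound 3 `CCOC(=O)c1cnc(-c2ccc(Cl)cc2)nc1NN1C(=O)C=C(C)C1=O` carries 4-chlorophenyl, and in this assay compound 3 gives 300 nM. The steps of a 3.5-fold higher number from compound 1 to compound 2 (0.54 log units; beyond the scatter) and a 2.3-fold lower number from compound 2 to compound 3 (0.37 log units; beyond the scatter) are both modest, while a 1.5-fold higher number from compound 1 to compound 3 (0.18 log units; within the scatter).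

Compound 4 `CCOC(=O)c1cnc(S(=O)(=O)c2ccccc2)nc1NN1C(=O)C=C(C)C1=O` is not yet measured. (phenylsulfonyl in place of 4-fluorophenyl on an aromatic carbon). For the measured compounds named here, no measured step exchanges an aryl group for one joined through a sulfur bearing two oxygens, so the measured steps only bracket the likely outcome: all three numbers lie within a modest span, and the only other sulfur-linked group, in compound 1, gave 200 nM. The expected step is therefore a 1.8-fold lower number from compound 2 to compound 4 (0.24 log units; within the scatter), a lower number in this assay. For compound 4 the estimate is 400 nM, in the range 120 nM to 1500 nM.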

Compound 4, half-maximal inhibitory concentration: 10000 nM
For compound 4 the middle estimate is 25-fold (1.40 log units) below the measured one; the whole stated range lies below it.
By their numbers in this assay, from the lowest: compounds 1 and 3 (each within the scatter of the next); then compound 2; then compound 4.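

For the compounds shown here, this position tolerates much less than the earlier compounds suggested. In this assay, replacing the directly attached aryl groups with phenylsulfonyl gives a 14-fold higher number from compound 2 to compound 4 (1.15 log units; beyond the scatter) and a 33-fold higher number from compound 3 to compound 4 (1.52 log units; beyond the scatter), far larger changes than any seen among the first three compounds. The step to phenylsulfonyl from the other sulfur-linked group is a 50-fold higher number from compound 1 to compound 4 (1.70 log units; beyond the scatter), so a sulfur link alone does not keep the number low, and the six-membered aromatic ring that compound 4 shares with compound 2 and compound 3 does not do so either.

Nothing available explains why the number rises so sharply. A methylsulfonyl group would show whether the sulfonyl link or the phenyl ring attached to it matters more, and phenylsulfanyl would test the two oxygens directly.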